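A few compounds are considered here, and "the series" means these few. Any claim that something is new, unique, unknown or untested is made for them only; others in the source may bear on it.

Compound 2 `CC(C)COC(=O)N1CCCc2cc(S(=O)(=O)N3CC(c4ccccc4)NC3=O)ccc21` carries an isobutyl carbamate on the shared core, and compound 1 `COC(=O)N1CCCc2cc(S(=O)(=O)N3CC(c4ccccc4)NC3=O)ccc21` the methyl counterpart. In a functional assay on A549 cells (Homo sapiens) for antiproliferative activity, read by MTT assay (a lower number here means a stronger inhibitor, a higher number a weaker inhibitor), compound 2 sits at the assay limit, > 20000 nM, which is a limit rather than a number. In this assay compound 1 gives 1150 nM. Among the compounds with values here, the only measured step, an at least 17-fold higher number from compound 1 to compound 2 (1.24 log units; beyond the scatter), is large, and one of its ends rests on the limit (the limit of > 20000 nM in this assay, at which 1 of the 2 values shown sits). Compound 3 `O=C(c1ccccc1)N1CCCc2cc(S(=O)(=O)N3CC(c4ccccc4)NC3=O)ccc21` differs from compound 2 by phenyl in place of isobutoxy on a carbonyl carbon. Within the data shown here, no measured step exchanges an isobutoxy for a phenyl on this carbonyl carbon, so the step from compound 1 to compound 2 informs only indirectly: adding isopropyl on the carbamate chain carbon erased measurable activity, while compound 3 keeps a group of comparable size but drops the isobutoxy altogether. The direction in this assay is therefore open. Compound 3 is expected to regain some activity, an at least 4.0-fold lower number from compound 2 to compound 3 (0.60 log units; beyond the scatter), and is estimated at 5000 nM (range 800 nM to 30000 nM).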

Compound 3, half-maximal inhibitory concentration: 8140 nM
Estimate against measurement, compound 3: 1.6-fold (0.21 log units) below; the measured number falls inside the stated range.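

On this carbonyl carbon, activity does not depend on an alkoxy group: phenyl in place of isobutoxy gives an at least 2.4-fold lower number from compound 2 to compound 3 (0.39 log units; beyond the scatter). The true size of that step stays unknown, since compound 2 stands at a limit and not at a number: the limit of > 20000 nM in this assay, at which 1 of the 3 values shown sits. Phenyl in place of methoxy still gives a 7.1-fold higher number from compound 1 to compound 3 (0.85 log units; beyond the scatter), so in this assay compound 1 remains the strongest of the three, and neither larger group shown matches the methoxy.

Open, as far as these compounds go, is whether the rise in the number follows the size of the group on the carbonyl carbon or the loss of the oxygen link. An acetyl, an ethyl carbamate or an amine on this carbonyl carbon would separate those two readings, and a substituted phenyl would show whether the benzoyl can be improved.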